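Chloro for Methyl on the Sulfonamide Aryl of Compound 1

The source may report more compounds than this note shows. Statements on the series, on what has been measured and on what is new or still open speak of the compounds shown alone.

Compound 1: `Cc1ccc(S(=O)(=O)Nc2ccc3c(c2)c(Cc2ccc(F)cc2)cn3CCC(=O)O)cc1`, 0.269 nM
Compound 2: `O=C(O)CCCc1ccc(NS(=O)(=O)c2ccc(Cl)cc2)cc1`, 100 nM
Compound 3: `O=C(O)CCn1ccc2cc(NS(=O)(=O)c3ccc(F)cc3)ccc21`, 3.72 nM

Of the compounds shown here, three have been measured in a functional assay on aorta for antagonist activity at thromboxane A2 receptor (Rattus norvegicus); on this read-out lower numbers stand for tighter binding and higher numbers for weaker binding. Compound 1 gives 0.269 nM, the lowest of the three numbers. Its nearest neighbour on this read-out is compound 3, at 3.72 nM, a gap that lies beyond the scatter, and the furthest is compound 2, at 100 nM, also well beyond the scatter. No pair among these three differs in only one place, so no single-point step can be read from them.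

Compound 4, `O=C(O)CCn1cc(Cc2ccc(F)cc2)c2cc(NS(=O)(=O)c3ccc(Cl)cc3)ccc21`, has not yet been measured in this assay. It differs from compound 1 in one place only: chloro in place of methyl on an aromatic carbon. Going by the values given here, the change sits on the six-membered aromatic ring of carbon only that carries the sulfonyl group; the rest of the shared core of compound 1 is unchanged.

Among the compounds with values here, nothing among the measured compounds shows how a 4-methylphenyl to 4-chlorophenyl exchange alone moves this read-out. Compound 4 is therefore expected to stay close to compound 1, with a step of a 1.1-fold higher number from compound 1 to compound 4 (0.05 log units; within the scatter) that is estimated to fall within the scatter in either direction. The estimate for compound 4 is 0.3 nM, with a range from 0.1 nM to 1 nM.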

Compound 4, dissociation constant: 0.234 nM
For compound 4 the middle estimate is 1.3-fold (0.11 log units) above the measured one; measured number inside the range.
By their numbers in this assay, from the lowest: compounds 4 and 1 (each within the scatter of the next); then compound 3; then compound 2.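

In this assay, going by these compounds alone, putting chloro in place of methyl on an aromatic carbon, para to a large group, gives a 1.1-fold lower number from compound 1 to compound 4 (0.06 log units; within the scatter), the first step in this set that changes one place only. On this read-out, then, 4-methylphenyl and 4-chlorophenyl on the sulfonyl group cannot be told apart, and the low nanomolar-range number of the shared core stands with either group at this position. No measurement at hand says why the two groups read alike.

A single exchange between two groups with one heavy atom each leaves open how this position responds to anything else, such as a hydrogen, a methoxy group, an amine or a carboxylic acid, and whether a larger group there would still read the same. The compounds shown also give no single-place step for the rest of the molecule, so what the 4-fluorophenylmethyl group contributes on its own, or how a longer chain carrying the carboxylic acid would read, remains unsettled.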